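A few compounds are considered here, and "the series" means these few. Any claim that something is new, unique, unknown or untested is made for them only; others in the source may bear on it.

Measured in a functional assay on MCF7 cells (Homo sapiens) for antiproliferative activity, read by CCK-8 assay and cell counting, with a stated time of 72 h; on this read-out lower numbers stand for stronger inhibition and higher numbers for weaker inhibition:
- compound 1 `O=C(Nc1ccccc1)c1ccc(CCl)cc1`: 54300 nM
- compound 2 `O=C(Nc1ccccc1)c1ccc(CO[N+](=O)[O-])cc1`: > 100000 nM (a limit)

Compound 2 has no number, only a limit: the limit of > 100000 nM in this assay, at which 1 of the 2 values shown sits.

Compound 3 `CCc1ccc(C(=O)Nc2ccccc2)cc1` is the next step: methyl in place of nitrooxy on a saturated chain carbon bound to an aromatic carbon. This puts methyl in place of nitrooxy on a saturated chain carbon bound to an aromatic carbon, or (nitrooxy)methyl to ethyl.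

Among the compounds with values here, the one measured step at this carbon, an at least 1.8-fold higher number from compound 1 to compound 2 (0.26 log units; that floor lies within the scatter), has a floor within the scatter, so no step beyond the scatter is expected in this assay. The expected step is an at least 1.2-fold lower number from compound 2 to compound 3 (0.09 log units; that floor lies within the scatter). The estimate for compound 3 is 80000 nM, with an expected range of 30000 nM to 200000 nM.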

Compound 3, half-maximal inhibitory concentration: > 100000 nM
Compound 3 was reported as a limit (the forecaster's own chance of this, stated with the estimate: 50%); middle value at least 1.2-fold (0.09 log units) away from the limit.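

Compound 3 gives > 100000 nM, which is a limit and not a number, and ethyl thus joins (nitrooxy)methyl at the limit: the limit of > 100000 nM in this assay, at which 2 of the 3 values shown sit.

Methyl in place of chloro gives an at least 1.8-fold higher number from compound 1 to compound 3 (0.26 log units; that floor lies within the scatter), leaving the chloro of compound 1 the only group at this carbon with a measured number so far. The step between compound 2 and compound 3 cannot be read, as both are limits.

Still open, as far as these compounds go, is whether an amine, a carboxylic acid or a longer chain at this carbon would give a number inside the range of the assay.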